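The source may report more compounds than this note shows. Statements on the series, on what has been measured and on what is new or still open speak of the compounds shown alone.

Compound 3, `CS(=O)(=O)c1cccc(C#Cc2cc(Cl)ccc2OCC(=O)O)c1`, is the anchor of this set. In an assay on CHO cells for displacement of a labelled ligand from prostaglandin D2 receptor 2 (Homo sapiens), read by scintillation counting (a lower number here means a stronger inhibitor, a higher number a weaker inhibitor), compound 3 gives 15 nM, the second highest of the three numbers recorded so far. Compound 2, `COc1ccc(-c2ccc(C#Cc3cc(Cl)ccc3OCC(=O)O)cc2S(C)(=O)=O)cc1`, gives 7 nM in this assay, and compound 1, `CS(=O)(=O)Cc1cccc(C#Cc2cc(Cl)ccc2OCC(=O)O)c1`, gives 48 nM. The two steps that reach compound 3 are a 3.2-fold lower number from compound 1 to compound 3 (0.51 log units; beyond the scatter) and a 2.1-fold higher number from compound 2 to compound 3 (0.33 log units; beyond the scatter).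

Compound 4, `CS(=O)(=O)c1ccc(Cl)c(C#Cc2cc(Cl)ccc2OCC(=O)O)c1`, differs from compound 3 by chloro in place of hydrogen on an aromatic carbon, entering on the ring that carries the methylsulfonyl group, ortho to a large group and para to that methylsulfonyl. Going by the values given here, no measured step adds a chloro, so none bears on it directly. The nearest comparison is the step from compound 2 to compound 3, where removing a large substituent from this same ring cost a modest amount; a single chlorine is a far smaller addition, so any effect in this assay is expected to be small, at most a modest lowering.

Compound 4 is therefore expected to give about 10 nM in this assay, within 4 nM to 25 nM, an expected step of a 1.5-fold lower number from compound 3 to compound 4 (0.18 log units; within the scatter).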

Compound 4, inhibition constant: 3.5 nM
For compound 4 the middle estimate is 2.9-fold (0.46 log units) above the measured one; measured number outside the range, below it.
By their numbers in this assay, from the lowest: compounds 4 and 2 (each within the scatter of the next); then compound 3; then compound 1.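

A single chloro group on the ring carrying the methylsulfonyl group, ortho to a large group and para to that methylsulfonyl, gives a 4.3-fold lower number from compound 3 to compound 4 (0.63 log units; beyond the scatter) in this assay. The earlier steps shown here changed the methylsulfonyl group or removed 4-methoxyphenyl; this one shows that adding one heavy atom at this place, with no hydrogen-bond donor or acceptor, also moves the number beyond the scatter. No available measurement accounts for this lowering.

The compounds shown leave open whether the step is specific to chloro or would also appear with fluoro, bromo or a methyl group at the same place. They also leave open whether an amine or a methoxy group there would lower the number, raise it or leave it unchanged.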